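The source may hold more compounds than are shown below. What is called first, only, known or untested is meant among the compounds shown, and "the series" means these compounds.

Compound 1 `CC(C)C(=O)Nc1nc(CN=C=S)cs1`: 8200 nM
Compound 2 `CC(C)(C)C(=O)Nc1nc(CN=C=S)cs1`: 4300 nM
Compound 3 `CC(=O)Nc1nc(CN=C=S)c[se]1`: 30000 nM

Of the compounds shown here, three have so far been tested in a functional assay on L1210 cells (Mus musculus) for antiproliferative activity; a higher number here means a weaker inhibitor, a lower number a stronger inhibitor. Compound 1 and compound 2 share a core and differ only in methyl in place of hydrogen on a saturated chain carbon bound to a carbonyl carbon and two saturated chain carbons. The resulting step is a 1.9-fold lower number from compound 1 to compound 2 (0.28 log units; within the scatter), so the two cannot be told apart on this evidence. Compound 3 carries a different core; the difference between the two cores is not broken down here. In this assay compound 3 gives 30000 nM, the highest number of the three, and its gap to both compound 1 and compound 2 lies beyond the scatter.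

Compound 4 `CCC(=O)Nc1nc(CN=C=S)c[se]1` has not yet been measured. It differs from compound 3 by methyl in place of hydrogen on a saturated chain carbon bound to a carbonyl carbon. This is the same kind of change as that from compound 1 to compound 2, though not the same: in compound 1 the carbon that receives the methyl is bound to a carbonyl carbon and two saturated chain carbons, whereas in compound 3 it is bound to a carbonyl carbon only. Because the earlier step was a 1.9-fold lower number from compound 1 to compound 2 (0.28 log units; within the scatter), a similarly small step is expected here, a 1.4-fold lower number from compound 3 to compound 4 (0.13 log units; within the scatter). Compound 4 is therefore estimated at 22000 nM, with a range from 8000 nM to 60000 nM.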

Compound 4, half-maximal inhibitory concentration: 3500 nM
The estimate for compound 4 lay 6.3-fold (0.80 log units) above the measured number; the measured number lies below the stated range.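

In this assay, methyl in place of hydrogen on a saturated chain carbon bound to a carbonyl carbon gives an 8.6-fold lower number from compound 3 to compound 4 (0.93 log units; beyond the scatter), a step beyond the scatter on the core of compound 3. Set beside the earlier step, the change does not carry over at the same size from one core to the other: the same change on two cores in this assay, a 1.9-fold lower number (0.28 log units; within the scatter) from compound 1 to compound 2 and an 8.6-fold lower number (0.93 log units; beyond the scatter) from compound 3 to compound 4, 4.5-fold (0.65 log units) apart, beyond the scatter of two such steps This does not show why the two steps differ, since they differ both in the core and in the receiving carbon, which is bound to a carbonyl carbon only in compound 3 but also to two saturated chain carbons in compound 1, and two pairs cannot separate these or support a rule.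

No acyl group among the compounds shown stands on both cores, so it remains open how the cores compare when that group is held the same. Also open, on these data alone, is whether a longer chain such as butanoyl, or a carboxylic acid in place of the methyl, would change the number on the core of compound 3.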